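Hydroxyphenyl series: step from compound 2 to compound 4

The compounds below may be only part of what the source reports. "The series", "measured", "known", "first", "only" and "open" are said of these compounds alone.

Measured so far in a functional assay on T47D cells (Homo sapiens) for cytotoxicity, read by CCK-8 assay, with a stated time of 4 days; a lower number here means a stronger inhibitor, a higher number a weaker inhibitor:
compound 1, `Oc1ccc(-c2cc(-c3ccccc3O)cc(-c3cccc(O)c3)n2)cc1`, 650 nM
compound 2, `Oc1ccc(-c2cc(-c3ccc(O)cc3)nc(-c3ccc(O)cc3)c2)cc1`, 4270 nM
compound 3, `Oc1cccc(-c2cc(-c3ccccc3O)nc(-c3ccccc3O)c2)c1`, 3420 nM

Compound 2 gives the highest of the three numbers. Compound 3 lies within the scatter of it, so no order is claimed between them; compound 1 lies lower, beyond the scatter. Compound 4, `Oc1ccc(-c2cc(-c3cccc(O)c3)cc(-c3ccc(O)cc3)n2)cc1`, has the same atoms as compound 2, joined differently: 3-hydroxyphenyl in place of 4-hydroxyphenyl on an aromatic carbon. For the measured compounds named here, no measured pair differs in exactly this way, so the size of the step is open. Compound 1, which also carries a 3-hydroxyphenyl group, gives 650 nM in this assay, which hints at a downward direction. Expected, with wide uncertainty: a 1.7-fold lower number from compound 2 to compound 4 (0.23 log units; within the scatter), a modest step in this assay. Compound 4 is estimated at 2500 nM, range 900 nM to 7000 nM.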

Compound 4, half-maximal inhibitory concentration: 4070 nM
The estimate for compound 4 lay 1.6-fold (0.21 log units) below the measured number; measured number inside the range.
By their numbers in this assay, from the lowest: compound 1; then compounds 3, 4 and 2 (each within the scatter of the next).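

In this assay, 3-hydroxyphenyl in place of 4-hydroxyphenyl opposite the ring nitrogen, with the two 4-hydroxyphenyl groups kept, gives a 1.0-fold lower number from compound 2 to compound 4 (0.02 log units; within the scatter), so no effect of this change can be read at this place. A 3-hydroxyphenyl group here does not by itself give a number like that of compound 1 at 650 nM. Nothing available explains this result.

Still open, from the compounds shown here alone, is whether an aminophenyl or a methoxyphenyl group opposite the ring nitrogen would shift the number. Also open, going by these compounds, is whether the same hydroxyl shift matters on the other two rings.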